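This account rests on a few compounds, and the source may have more. Where it says the series, first, only, none or still open, it means among the compounds named here.

Compound 3 `Cc1cc(C(=O)NC2CC2)nn1Cc1cc(Cl)cc2cc(-c3ccccc3)oc12` gives 5.01 nM in an assay on CHO-K1 cells for displacement of a labelled ligand from prostaglandin E2 receptor EP1 subtype (Homo sapiens), read by scintillation counting, with a stated time of 45 min; on this read-out lower numbers stand for stronger inhibition and higher numbers for weaker inhibition. Among the three compounds measured, its number is the lowest, yet the steps of a 2.0-fold lower number from compound 1 to compound 3 (0.30 log units; within the scatter) and a 2.0-fold lower number from compound 2 to compound 3 (0.30 log units; within the scatter) both lie within the scatter, so nothing separates it from compound 1 `Cc1cc(C(=O)NN2CCOCC2)nn1Cc1cc(Cl)cc2cc(-c3ccccc3)oc12` at 10 nM or compound 2 `Cc1cc(C(=O)NC(C)C)nn1Cc1cc(Cl)cc2cc(-c3ccccc3)oc12` at 10 nM. Compound 4 `Cc1cc(C(=O)N[C@H]2CC[C@H](O)CC2)nn1Cc1cc(Cl)cc2cc(-c3ccccc3)oc12` carries 4-hydroxycyclohexyl in place of cyclopropyl on an amide-type nitrogen. All three measured steps alter the same amide-type nitrogen, and each, no change at the digits printed from compound 1 to compound 2 (within the scatter), a 2.0-fold lower number from compound 1 to compound 3 (0.30 log units; within the scatter) and a 2.0-fold lower number from compound 2 to compound 3 (0.30 log units; within the scatter), stayed within the scatter. A larger ring with a hydroxyl group has not been tried, so the expectation is only a step no larger than the scatter, a 1.4-fold higher number from compound 3 to compound 4 (0.15 log units; within the scatter). Compound 4 is therefore estimated at 7 nM, between 2.5 nM and 20 nM.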

Compound 4, half-maximal inhibitory concentration: 7.94 nM
For compound 4 the middle estimate is 1.1-fold (0.05 log units) below the measured one, and the stated range covers the measured number.
By their numbers in this assay, from the lowest: compounds 3, 4, 1 and 2 (each within the scatter of the next).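

Even 4-hydroxycyclohexyl, with its six-membered carbon ring and hydroxyl, stays within the scatter of every earlier group on this amide-type nitrogen in this assay (a 1.6-fold higher number from compound 3 to compound 4 (0.20 log units; within the scatter); a 1.3-fold lower number from compound 2 to compound 4 (0.10 log units; within the scatter); a 1.3-fold lower number from compound 1 to compound 4 (0.10 log units; within the scatter)). The range of groups here now extends from cyclopropyl to this much larger one, and the hydrogen-bond donor it brings produces no change that this read-out can separate. No evidence is available to explain this flat result. On these data alone, whether a carboxylic acid or an amine at the end of a longer chain on this nitrogen would move the number beyond the scatter remains open.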